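The source may report more compounds than this note shows. Statements on the series, on what has been measured and on what is new or still open speak of the compounds shown alone.

Measured so far:
compound 1 `Nc1scc(CN2CCN(c3ccc([N+](=O)[O-])cc3)CC2)c1C(=O)c1ccc(Cl)cc1` — -13%
compound 2 `Nc1scc(CN2CCN(c3ccccc3F)CC2)c1C(=O)c1ccc(Cl)cc1` — -1%
compound 3 `Nc1scc(CN2CCN(c3cccc(Cl)c3)CC2)c1C(=O)c1ccc(Cl)cc1` — -20%

In a functional assay on CHO cells with adenosine receptor A1 (Homo sapiens) as the target, read by cAMP accumulation and immunoassay, with a stated time of 6 min, tested at 0.1 uM (a higher number here means a weaker effect of the compound at the concentration tested, a lower number a stronger effect), compound 1 stands second highest of the three numbers; compound 3 lies nearest, with a number 7 percentage points lower from compound 1 to compound 3 (within the scatter), and compound 2 furthest, with a number 12 percentage points higher from compound 1 to compound 2 (beyond the scatter).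

Compound 4 `Nc1scc(CN2CCN(c3ccccc3Cl)CC2)c1C(=O)c1ccc(Cl)cc1` is not yet measured. It differs from compound 1 by 2-chlorophenyl in place of 4-nitrophenyl on an amine nitrogen in a ring. Among the compounds with values here, two measured steps bear on this change, both replacing the 4-nitrophenyl of compound 1: a number 12 percentage points higher from compound 1 to compound 2 (beyond the scatter) and a number 7 percentage points lower from compound 1 to compound 3 (within the scatter). A halogenated phenyl has thus given either a modest rise or a change within the scatter. For compound 4 a step of about a number 5 percentage points higher from compound 1 to compound 4 (within the scatter) is expected, likely within the scatter. Compound 4 is estimated at -8%, with a range from -22% to 6%.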

Compound 4, a percentage reported as activity, at one concentration (the size of the read-out at that concentration, not a potency): 2%
Estimate against measurement, compound 4: 10 percentage points below, within the range that was stated.
By their numbers in this assay, from the lowest: compounds 3 and 1 (each within the scatter of the next); then compounds 2 and 4 (each within the scatter of the next).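

In this assay, the place of the chlorine on the phenyl matters: moving from 3-chlorophenyl to 2-chlorophenyl gives a number 22 percentage points higher from compound 3 to compound 4 (beyond the scatter). Chloro in place of fluoro on the same aromatic carbon gives only a number 3 percentage points higher from compound 2 to compound 4 (within the scatter). Replacing 4-nitrophenyl with 2-chlorophenyl gives a number 15 percentage points higher from compound 1 to compound 4 (beyond the scatter), so the rise seen with compound 2 recurs with a second 2-halogenated phenyl, while compound 3 goes against it.

Nothing available explains these steps. From the compounds shown here alone, whether a 2-methoxyphenyl or an unsubstituted phenyl would sit with compounds 2 and 4 remains open.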